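Swapping an aryl for an acyl group on a ring amine

This account rests on a few compounds, and the source may have more. Where it says the series, first, only, none or still open, it means among the compounds named here.

Of the compounds shown here, two have so far been measured in a functional assay on Huh-7 cells (Homo sapiens) for antiproliferative activity, read by sulforhodamine B assay, with a stated time of 72 h; on this read-out higher numbers stand for weaker inhibition and lower numbers for stronger inhibition. Compound 1 `COc1cc(COc2ccc(-c3cc(CN4CCN(Cc5ccc(C(F)(F)F)cc5)CC4)no3)cc2)cc(OC)c1OC` gives 500 nM in this assay. Compound 2 `N#Cc1cccc(COc2ccc(-c3cc(CN4CCN(c5ccc(C(F)(F)F)cc5)CC4)no3)cc2)c1` gives 2200 nM in this assay, the highest of the two numbers; its nearest neighbour is compound 1, and the gap between them lies beyond the scatter, so compound 2 is the weaker of the pair. For the measured compounds named here, no step between measured compounds that differ in one place is available, so the pair offers only its two numbers and nothing more.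

Compound 3 `N#Cc1cccc(COc2ccc(-c3cc(CN4CCN(C(=O)C5CCCO5)CC4)no3)cc2)c1` has not yet been measured in this assay. It differs from compound 2 in one place: (oxolan-2-yl)carbonyl in place of 4-(trifluoromethyl)phenyl on an amine nitrogen in a ring. The group that enters carries a carbonyl and a five-membered ring with one hetero atom, whereas the group that leaves is an aromatic ring bearing trifluoromethyl. Going by the values given here, no measured pair shows what such an exchange does in this assay, so the expectation rests on compound 2 alone. A small step toward a higher number is expected, possibly within the scatter. The expected step is a 1.6-fold higher number from compound 2 to compound 3 (0.20 log units; within the scatter). For compound 3 the estimate in this assay is 3500 nM, with a range from 900 nM to 14000 nM.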

Compound 3, half-maximal inhibitory concentration: 2200 nM
Compound 3: middle estimate off by 1.6-fold (0.20 log units), on the high side, and the stated range covers the measured number.
By their numbers in this assay, from the lowest: compound 1; then compounds 2 and 3 (each within the scatter of the next).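

In this assay, for the compounds shown here, placing (oxolan-2-yl)carbonyl in place of 4-(trifluoromethyl)phenyl on the amine nitrogen in the ring gives no change at the digits printed from compound 2 to compound 3 (within the scatter), the first reading of a change at a single place in this set. At this position, therefore, a group with a carbonyl and a five-membered non-aromatic ring reads the same as the aromatic ring bearing trifluoromethyl, even though the entering group has fewer heavy atoms and two hydrogen-bond acceptors where the leaving group has none. No independent measurement bears on why these two different groups give matching numbers.

Compound 1 differs from compound 2 and compound 3 in more than one place, so its number cannot be tied to any single group. From the compounds shown here alone, it also remains open what an acetyl group, a free secondary amine or a longer chain ending in a carboxylic acid would do on this same ring nitrogen, and whether the match between compound 2 and compound 3 would hold for them.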